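This account rests on a few compounds, and the source may have more. Where it says the series, first, only, none or still open, it means among the compounds named here.

Compound 2 `C/C=C/C=C/C(=O)N[C@H](C(=O)NCCCCCCCCCCCC)[C@@H](C)O` carries a long saturated chain on one amide and a dienoyl group on the other. In a functional assay on SW-620 cells (Homo sapiens) for cytotoxicity, read by MTT assay, with a stated time of 48 h (a higher number here means a weaker inhibitor, a lower number a stronger inhibitor), compound 2 gives 200000 nM. Compound 1 `CCCCCCCCCCCCNC(=O)[C@@H](NC(=O)c1ccccc1)[C@@H](C)O`, with a benzoyl group instead, gives 200000 nM, and the step of no change at the digits printed from compound 1 to compound 2 (within the scatter) lies within the scatter, so the two stand level and together at the top of the three numbers seen. Compound 3 `CCCCCCCCCCCCNC(=O)[C@@H](NS(=O)(=O)c1cccs1)[C@@H](C)O` gives 27900 nM; the steps of a 7.2-fold lower number from compound 1 to compound 3 (0.86 log units; beyond the scatter) and a 7.2-fold lower number from compound 2 to compound 3 (0.86 log units; beyond the scatter) are both modest and beyond the scatter.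

Compound 4 `C/C=C/C=C/C(=O)N[C@H](C(=O)NCCCCCCCCCCCCCCCCCC)[C@@H](C)O` differs from compound 2 only in the long chain: hexyl in place of hydrogen on a saturated chain carbon, ten or more bonds along the chain from an amide-type nitrogen. For the measured compounds named here, every measured step so far changes the group on the amine nitrogen, not the chain, so none of them bears directly on this change. The numbers for compound 1 and compound 2 sit at the same value regardless of the acyl group, which suggests that this chemotype is near the weak end of what the assay can resolve. Going by the values given here, with no step to lean on, the expectation is a change of no more than the scatter.

Compound 4 is therefore estimated at 160000 nM, with a range from 50000 nM to 400000 nM; the expected step of a 1.3-fold lower number from compound 2 to compound 4 (0.10 log units; within the scatter) is small.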

Compound 4, half-maximal inhibitory concentration: 200000 nM
The estimate for compound 4 lay 1.3-fold (0.10 log units) below the measured number; measured number inside the range.
By their numbers in this assay, from the lowest: compound 3; then compounds 1, 2 and 4 (each within the scatter of the next).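

This is the only step shown that changes the long saturated chain rather than the group on the amine nitrogen, and adding hexyl at this place gives no change at the digits printed from compound 2 to compound 4 (within the scatter) in this assay. With the dienoyl group in place, the reading is therefore insensitive to this extension of the chain, just as it was to the exchange of the group on the nitrogen in the step with no change at the digits printed from compound 1 to compound 2 (within the scatter) as its result. No independent measurement is available to account for this result.

For the compounds shown here, because only the dienoyl compounds carry this comparison, it remains open whether the same hexyl extension would matter alongside the thiophene sulfonyl group of compound 3, which gives 27900 nM in this assay and is the only compound here that stands apart from the others. Also open, from the compounds shown here alone, is whether a chain ending in an amine or a carboxylic acid, rather than in a plain saturated carbon, would shift the number at all.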